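The source may hold more compounds than are shown below. What is called first, only, known or untested is meant among the compounds shown, and "the series" means these compounds.

Measured in a functional assay on K562 cells (Homo sapiens) for cytotoxicity, read by sulforhodamine B assay, with a stated time of 48 h; a higher number here means a weaker inhibitor, a lower number a stronger inhibitor:
Compound 1 `CCn1cc(-c2nc3ccccc3[nH]2)c(=O)c2cc(F)c(N3CCNCC3)nc21`: 9100 nM
Compound 2 `CCn1cc(-c2nc3ccc([N+](=O)[O-])cc3o2)c(=O)c2cc(F)c(N3CCNC(C)C3)c(F)c21`: 4600 nM

Compound 1 stands level with compound 2, as their two values lie within the usual scatter of repeated measurements. Compound 3 `CCn1cc(-c2nc3ccc(N)cc3[nH]2)c(=O)c2cc(F)c(N3CCNCC3)nc21` is built from compound 1 by one change, amino in place of hydrogen on an aromatic carbon. The new group sits on a six-membered aromatic ring of carbon only, part of a fused or bridged system of two rings. Within the data shown here, no pair of measured compounds differs in one place, so the data offer no direct guide to this change. In this assay a small step toward a lower number, close to the scatter, is expected. The expected change is a 1.3-fold lower number from compound 1 to compound 3 (0.11 log units; within the scatter). For compound 3 the estimated value is 7000 nM, with an expected range from 2500 nM to 20000 nM.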

Compound 3, half-maximal inhibitory concentration: > 10000 nM
Compound 3 gave a limit, no number; the forecaster's own chance of this, stated with the estimate: 15%; at least 1.4-fold (0.15 log units) between middle value and limit.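

Among these compounds, this is the first reading of a single change on the shared core: amino in place of hydrogen on an aromatic carbon of the six-membered aromatic ring of carbon only. Compound 3 gives a limit and not a number in this assay: the limit of > 10000 nM in this assay, at which 1 of the 3 values shown sits. The step is an at least 1.0-fold higher number from compound 1 to compound 3 (0.04 log units; that floor lies within the scatter), so the amino group brought no move toward a lower number, and how far compound 3 truly lies from compound 1 cannot be read.

As far as these compounds go, whether another group on this carbon, such as a hydroxyl, a methoxy or a carboxylic acid, would give a lower number remains open. The nitro group of compound 2 cannot be set against the amino group of compound 3, as those two compounds differ in more than one place.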